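Moving a methyl group on a phenyl ring

A few compounds are considered here, and "the series" means these few. Any claim that something is new, unique, unknown or untested is made for them only; others in the source may bear on it.

Compound 1 `O=C1OC[C@H](Cc2ccccc2O)[C@H]1Cc1ccc(Cl)c(Cl)c1` gives 33000 nM
Compound 2 `COc1cccc(C[C@H]2COC(=O)[C@@H]2Cc2ccc(Cl)c(Cl)c2)c1` gives 34000 nM
Compound 3 `Cc1cccc(C[C@H]2COC(=O)[C@@H]2Cc2ccc(Cl)c(Cl)c2)c1` gives 22000 nM

On these numbers from a functional assay on HL-60 cells (Homo sapiens) for cytotoxicity, read by WST assay, with a stated time of 48 h (on this read-out lower numbers stand for an effect already at smaller amounts and higher numbers for an effect only at larger amounts of compound), compound 3 stands level with the other two compounds. The measured steps are a 1.5-fold lower number from compound 1 to compound 3 (0.18 log units; within the scatter) and a 1.5-fold lower number from compound 2 to compound 3 (0.19 log units; within the scatter) and also a 1.0-fold higher number from compound 1 to compound 2 (0.01 log units; within the scatter) and none of them goes beyond the scatter.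

The next compound is compound 4 `Cc1ccc(C[C@H]2COC(=O)[C@@H]2Cc2ccc(Cl)c(Cl)c2)cc1` and it keeps the shared core of compound 3. The change is 4-methylphenyl in place of 3-methylphenyl on a saturated chain carbon bound to a saturated ring carbon and in words it puts 4-methylphenyl in place of 3-methylphenyl on a saturated chain carbon bound to a saturated ring carbon.

All three measured steps altered this same aromatic group, so they are the ones that bear on the change. None of them shows this exact exchange, which makes the evidence indirect. Still, the swaps seen so far, including a 1.5-fold lower number from compound 2 to compound 3 (0.19 log units; within the scatter) as the one that involves a methyl group, stayed small. No step beyond the scatter is therefore expected in this assay in either direction. The expected change is a 1.1-fold higher number from compound 3 to compound 4 (0.04 log units; within the scatter) and this estimate stays close to the starting point. For compound 4 the estimated value is 24000 nM with an expected range from 11000 nM to 48000 nM and the measurement is still to come.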

Compound 4, half-maximal effective concentration: 19000 nM
For compound 4 the middle estimate is 1.3-fold (0.10 log units) above the measured one, within the range that was stated.
By their numbers in this assay, from the lowest: compounds 4, 3, 1 and 2 (each within the scatter of the next).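

For the compounds shown here, this is the first direct look at moving the methyl group on the phenyl ring: in this assay, 4-methylphenyl in place of 3-methylphenyl gives a 1.2-fold lower number from compound 3 to compound 4 (0.06 log units; within the scatter), so the two placements cannot be told apart. The larger swaps read the same way, with a 1.8-fold lower number from compound 2 to compound 4 (0.25 log units; within the scatter) for 4-methylphenyl in place of 3-methoxyphenyl and a 1.7-fold lower number from compound 1 to compound 4 (0.24 log units; within the scatter) for 4-methylphenyl in place of 2-hydroxyphenyl, so in this assay all four aromatic groups on a saturated chain carbon bound to a saturated ring carbon stand level, even though these swaps change more of the group than the methyl move does. No measurement is available that could explain this lack of separation.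

Going by these compounds, it remains open whether any group at this place would give a step beyond the scatter, for instance an amine, a carboxylic acid or a longer chain on the phenyl ring in place of the methyl. On these data alone, all four compounds also keep the rest of the shared core unchanged, so how the number would respond to a change there is still unknown.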